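Dropping the Ethenyl Bridge: What to Expect for Compound 4

This account rests on a few compounds, and the source may have more. Where it says the series, first, only, none or still open, it means among the compounds named here.

Compound 2 `COC(=O)/C=C/c1cccc(N(Cc2ccc(/C=C/c3cccc(Cl)c3)cc2)C(=O)C(C)C)c1` gives 162 nM in an assay on isolated protein with Bile acid receptor (Homo sapiens) as the target (a lower number here means that less compound is needed, a higher number that more compound is needed for the effect), the second highest of three numbers, yet within the scatter of compound 1 `COC(=O)/C=C/c1cccc(N(Cc2ccc(/C=C/c3c(Cl)cccc3Cl)cc2)C(=O)C2CCCCC2)c1` at 151 nM and of compound 3 `COC(=O)/C=C/c1cccc(N(Cc2ccc(/C=C/c3ccc(F)cc3)cc2)C(=O)C2CCCCC2)c1` at 186 nM. Compound 4 `COC(=O)/C=C/c1cccc(N(Cc2ccc(-c3ccc(F)c(Cl)c3)cc2)C(=O)C(C)C)c1` differs from compound 2 by 3-chloro-4-fluorophenyl in place of 2-(3-chlorophenyl)ethenyl on an aromatic carbon. The only measured step touching this part of the molecule, a 1.2-fold higher number from compound 1 to compound 3 (0.09 log units; within the scatter), exchanged the ring on the ethenyl chain without leaving the scatter; no measured pair removes the double bond itself, so that part of the change has no precedent among these compounds. A modest rise in the number is therefore expected, a 2.0-fold higher number from compound 2 to compound 4 (0.30 log units; within the scatter), with wide uncertainty. Compound 4 is estimated at 320 nM, within 100 nM to 1200 nM.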

Compound 4, half-maximal effective concentration: 129 nM
Beside the measured number, compound 4's estimate is 2.5-fold (0.39 log units) above it, within the range that was stated.
By their numbers in this assay, from the lowest: compounds 4, 1, 2 and 3 (each within the scatter of the next).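

In this assay, exchanging 2-(3-chlorophenyl)ethenyl for 3-chloro-4-fluorophenyl gives a 1.3-fold lower number from compound 2 to compound 4 (0.10 log units; within the scatter). Within the data shown here, the double bond outside aromatic rings can thus leave this place with the number staying within the scatter, something the earlier compounds, all of which carry an ethenyl chain here, could not show. Nothing available explains this result. The compounds shown do not separate the loss of the double bond from the added fluorine. Also open, going by these compounds, is what an amine at this ring, or a carboxylic acid in place of the methyl ester, would give.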